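The source may hold more compounds than are shown below. What is called first, only, known or untested is meant among the compounds shown, and "the series" means these compounds.

In a functional assay on PC-3M cells (Homo sapiens) for antiproliferative activity, read by microscopy, with a stated time of 24 h (on this read-out lower numbers stand for stronger inhibition and higher numbers for weaker inhibition), compound 1 `Cc1c(C)n(Cc2ccccc2)c2ncn(C3CCOCC3)c(=N)c12` gives > 20000 nM. That value is a limit of the assay and not a number, so compound 1 has no exact position on the scale. Compound 4 `Cc1c(C)n(Cc2ccccc2)c2ncn(CCCO)c(=N)c12` carries 3-hydroxypropyl in place of oxan-4-yl on an aromatic nitrogen. For the measured compounds named here, no pair of measured compounds differs in just one place, so no measured step shows what this swap does. The closest guide is compound 2 `N=c1c2c(-c3ccccc3)c(-c3ccccc3)n(CC3CCCCC3)c2ncn1CCCO`, which also carries 3-hydroxypropyl on an aromatic nitrogen, along with other groups elsewhere, and gives 27700 nM; 26900 nM (2 entries). Compound 3 `N=c1c2c(-c3ccccc3)c(-c3ccccc3)n(CC3CC3)c2ncn1CC1CCOCC1` gives 34400 nM; 33900 nM (2 entries). Given the value of compound 2 at 27700 nM; 26900 nM (2 entries), no gain in potency beyond the scatter is expected from this swap. The estimated change is a step that the limit leaves unreadable from compound 1 to compound 4. A result reported only as a limit would be no surprise. For compound 4 the expected value in this assay is 30000 nM, with an estimated range from 15000 nM to 60000 nM.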

Compound 4, half-maximal inhibitory concentration: > 20000 nM
Compound 4 ended at the assay's limit (the forecaster's own chance of this, stated with the estimate: 65%); the middle value does not contradict the limit.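

In this assay compound 1 and compound 4 each give only a limit and not a number, and no step can be read between them. Going by these compounds, what 3-hydroxypropyl in place of oxan-4-yl does to the antiproliferative activity of the shared core remains open.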